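Carbamate in place of benzamide on the shared core

The source may hold more compounds than are shown below. What is called first, only, known or untested is meant among the compounds shown, and "the series" means these compounds.

Measured so far:
compound 1 `O=C(Nc1ccc(O)c2c(=O)cc(-c3ccccc3Cl)oc12)c1ccccc1`, 13000 nM
compound 2 `O=C(Nc1c(O)cc(O)c2c(=O)cc(-c3ccccc3Cl)oc12)c1ccccc1`, "not determined" (no result reported)
compound 3 `CC(C)C[C@H](NC(=O)OC(C)(C)C)C(=O)Nc1ccc(O)c2c(=O)cc(-c3ccccc3Cl)oc12`, 5100 nM

In a functional assay on ID8 cells (Mus musculus) for antiproliferative activity (a lower number here means a stronger inhibitor, a higher number a weaker inhibitor), compound 1 gives 13000 nM. This is the higher of the two numbers available, so compound 1 is the weaker inhibitor of the two; compound 3, the nearest entry, gives 5100 nM, and the gap between compound 3 and compound 1 lies beyond the scatter. Within the data shown here, compound 2 carries an additional hydroxyl on the shared core but has no result in this assay, so it offers no bearing on the step considered here.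

The compound to be measured next is compound 4 `CCC(C)OC(=O)Nc1ccc(O)c2c(=O)cc(-c3ccccc3Cl)oc12`. It differs from compound 1 in a single place: sec-butoxy in place of phenyl on a carbonyl carbon. Put more fully, benzoyl is exchanged for sec-butoxycarbonyl, and the benzamido group becomes a (sec-butoxycarbonyl)amino group; the nitrogen and carbonyl are kept.

Among the measured compounds shown here, no step between two measured compounds isolates this change, so any expectation rests on the two numbers at hand. Compound 3, which gives 5100 nM, also carries a carbamate within its side chain, though attached differently, and stands at a lower number than compound 1. For compound 4 the step from compound 1 is therefore expected to run toward a lower number, of modest size and close to the scatter: a 1.6-fold lower number from compound 1 to compound 4 (0.21 log units; within the scatter). Compound 4 is accordingly estimated at 8000 nM, with a range from 2500 nM to 25000 nM.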

Compound 4, half-maximal inhibitory concentration: 18000 nM
Beside the measured number, compound 4's estimate is 2.3-fold (0.35 log units) below it, and the stated range covers the measured number.
By their numbers in this assay, from the lowest: compound 3; then compounds 1 and 4 (each within the scatter of the next).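

In this assay, among these compounds, sec-butoxy in place of phenyl on a carbonyl carbon gives a 1.4-fold higher number from compound 1 to compound 4 (0.14 log units; within the scatter), the only step that isolates a single place on the shared core. This read-out therefore does not separate the benzamido group from the (sec-butoxycarbonyl)amino group, even though the six-membered aromatic ring leaves and a chain without a ring, carrying a hydrogen-bond acceptor, enters while the nitrogen and carbonyl are kept. No measurement at hand bears on why this exchange leaves the number within the scatter.

On these data alone, it remains open whether a simple amine or a carboxylic acid on the end of a chain at this carbonyl carbon, or a longer chain in place of sec-butoxy, would move the number beyond the scatter. The additional hydroxyl of compound 2 cannot be read without a result, and compound 3 differs from compound 1 and compound 4 in more than one place, so its number cannot be set against this step.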